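A few compounds are considered here, and "the series" means these few. Any claim that something is new, unique, unknown or untested is made for them only; others in the source may bear on it.

Measured so far:
Compound 1 `COc1ccccc1NC(=O)Oc1cc(=O)n(CCCO)c2c1CC(CC=C(C)C)C(C)(C)C2` gave 0% in a functional assay on PANC-1 cells (Homo sapiens) for inhibition, read by MTT assay, with a stated time of 24 h, tested at 10 uM; on this read-out lower numbers stand for less inhibition and higher numbers for more inhibition at the one concentration tested (going by the name of the read-out).
Compound 2 `CC(C)=CCC1Cc2c(OC(=O)Nc3ccc(F)c(F)c3)cc(=O)n(CCCO)c2CC1(C)C` gave 0% in this assay.

Compound 2 stands level with compound 1 on the numbers: the step of no change at the digits printed from compound 1 to compound 2 (within the scatter) shows no change within the scatter, so neither compound inhibits the cells to a measurable degree at the single concentration tested.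

Compound 3 `CC(C)=CCC1Cc2c(OC(=O)Nc3ccc(F)c(Cl)c3)cc(=O)n(CCCO)c2CC1(C)C` differs from compound 2 by chloro in place of fluoro on an aromatic carbon. Among the measured compounds shown here, the only measured step that bears on this, the step of no change at the digits printed from compound 1 to compound 2 (within the scatter), also swapped the group on the same ring, and it left the read-out unmoved. With both measured compounds sitting at the bottom of the scale and a swap of one halogen for another on that ring, the step of a number 3 percentage points higher from compound 2 to compound 3 (within the scatter) is expected to be none beyond the scatter. Compound 3 is therefore estimated at 3%, with a range from 0% to 18%.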

Compound 3, a percentage reported as inhibition, at one concentration (the size of the read-out at that concentration, not a potency): 0%
For compound 3 the middle estimate is 3 percentage points above the measured one; the measured number falls inside the stated range.
By their numbers in this assay, from the lowest: compounds 1, 2 and 3 (each within the scatter of the next).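

In this assay the read-out shows no change at the digits printed from compound 2 to compound 3 (within the scatter), so chloro in place of fluoro on this aromatic carbon, ortho to a fluoro group, leaves the compound at the bottom of the scale. Setting 3-chloro-4-fluorophenyl in place of 2-methoxyphenyl on the amide-type nitrogen gives the same picture, with no change at the digits printed from compound 1 to compound 3 (within the scatter), so all three phenyl groups shown on that nitrogen now read alike at the one concentration tested. No measurement at hand offers an explanation for this flat result.

From the compounds shown here alone, whether a different kind of group on the phenyl ring, such as an amine or a carboxylic acid, would move the read-out remains open. So does whether a longer chain elsewhere on the shared core would do so, since all three compounds sit at the same level and give no trend to follow.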